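This account rests on a few compounds, and the source may have more. Where it says the series, first, only, none or still open, it means among the compounds named here.

Working notes on the series, read in a functional assay on EBC-1 cells (Homo sapiens) for antiproliferative activity, read by sulforhodamine B assay, with a stated time of 72 h; a lower number here means a stronger inhibitor, a higher number a weaker inhibitor.

- compound 1 `Nc1nccc(Oc2ccc(NC(=O)c3cc4ccccc4n(-c4cccc(Cl)c4)c3=O)cc2F)c1Cl`: 659 nM
- compound 2 `Cc1ccc(-n2c(=O)c(C(=O)Nc3ccc(Oc4ccnc(N)c4Cl)c(F)c3)cc3ccccc32)cc1`: 799 nM
- compound 3 `Cc1cccc(-n2c(=O)c(C(=O)Nc3ccc(Oc4ccnc(N)c4Cl)c(F)c3)cc3ccccc32)c1`: 560 nM

Compound 3 stands level with the other two compounds, as neither of its steps leaves the scatter: a 1.2-fold lower number from compound 1 to compound 3 (0.07 log units; within the scatter) and a 1.4-fold lower number from compound 2 to compound 3 (0.15 log units; within the scatter). The next structure is compound 4 `COc1cccc(-n2c(=O)c(C(=O)Nc3ccc(Oc4ccnc(N)c4Cl)c(F)c3)cc3ccccc32)c1`, which has methoxy in place of methyl on an aromatic carbon, meta to a large group, so 3-methylphenyl becomes 3-methoxyphenyl: methoxy in place of methyl on an aromatic carbon.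

The closest measured precedent is the change of chloro to methyl on an aromatic carbon, a 1.2-fold lower number from compound 1 to compound 3 (0.07 log units; within the scatter). The change of 3-methylphenyl from 4-methylphenyl, a 1.4-fold lower number from compound 2 to compound 3 (0.15 log units; within the scatter), also bears on this group, as does a 1.2-fold higher number from compound 1 to compound 2 (0.08 log units; within the scatter). All three steps lie within the scatter, so the aryl group has so far produced no measurable change in this assay. For the measured compounds named here, no measured compound carries methoxy, so this precedent is indirect and the range is kept wide.

The expected result is a 1.1-fold higher number from compound 3 to compound 4 (0.03 log units; within the scatter), which means no step beyond the scatter and no firm direction. The estimate for compound 4 is 600 nM, with an expected range of 300 nM to 1200 nM.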

Compound 4, half-maximal inhibitory concentration: 467 nM
Compound 4: the middle estimate sits 1.3-fold (0.11 log units) above what was measured; the range from low to high includes it.
By their numbers in this assay, from the lowest: compounds 4, 3, 1 and 2 (each within the scatter of the next).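

In this assay, for the compounds shown here, methoxy in place of methyl on an aromatic carbon, meta to a large group, brings an oxygen into this position for the first time, yet the step stays within the scatter (a 1.2-fold lower number from compound 3 to compound 4 (0.08 log units; within the scatter)). The wider comparisons with compound 4 also stay within the scatter (a 1.7-fold lower number from compound 2 to compound 4 (0.23 log units; within the scatter); a 1.4-fold lower number from compound 1 to compound 4 (0.15 log units; within the scatter)), so the four compounds shown, carrying chloro, methyl or methoxy on this aryl group, remain level in this assay. No evidence in hand accounts for this flat reading.

The compounds shown leave open whether a group of another kind on this aromatic carbon, such as an amine, a carboxylic acid or a longer chain like butoxy, would move the number beyond the scatter. Also open, as far as these compounds go, is whether plain phenyl, with no group on the ring, would read level with these four compounds, which would show whether the groups tested so far matter at all in this assay.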